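The source may report more compounds than this note shows. Statements on the series, on what has been measured and on what is new or still open speak of the compounds shown alone.

Measured set in an ADME assay on HepG2 cells (Homo sapiens) for cytotoxicity, read by trypan blue exclusion, with a stated time of 48 h, in the presence of a further agent that is not named here; on this read-out higher numbers stand for lower toxicity in this test and lower numbers for higher toxicity in this test:
Compound 1, `COc1ccc2nc(C)cc(OCC(=O)Nc3ccccc3)c2c1`: compound 1 gives > 155000 nM, which is a limit of the assay.
Compound 2, `COc1ccc2nc(C)cc(OCC(=O)Nc3ccccc3Cl)c2c1`: compound 2 gives > 140000 nM, also a limit of the assay.
Compound 3, `COc1ccc2nc(C)cc(OCC(=O)Nc3ccc(Cl)cc3)c2c1`: compound 3 gives 89900 nM.

For the measured compounds named here, compound 3 thus holds the only actual number among the three; the other two values are limits. The step to compound 4, `COc1ccc2nc(C)cc(OCC(=O)NCCCc3ccccc3)c2c1`, is 3-phenylpropyl in place of 4-chlorophenyl on an amide-type nitrogen. The measured steps touch the substituent on the amide nitrogen only through the chloro pattern: an at least 1.7-fold lower number from compound 1 to compound 3 (0.23 log units; that floor lies within the scatter), an at least 1.5-fold lower number from compound 2 to compound 3 (0.19 log units; that floor lies within the scatter), and a step that the two limits leave unreadable from compound 1 to compound 2. Going by the values given here, none of them is known to exceed the scatter, and no measured step exchanges an aryl group for a chain on this nitrogen. For compound 4 no shift beyond the scatter is expected, a 1.3-fold higher number from compound 3 to compound 4 (0.13 log units; within the scatter), with a fair chance that only a limit is reported. Compound 4 is therefore estimated at 120000 nM, within 55000 nM to 260000 nM.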

Compound 4, half-maximal cytotoxic concentration: > 137000 nM
Compound 4 ended at the assay's limit; the forecaster's own chance of this, stated with the estimate: 50%; middle value at least 1.1-fold (0.05 log units) away from the limit.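

In this assay, for the compounds shown here, the first exchange of an aryl group for a chain on this amide-type nitrogen gives an at least 1.5-fold higher number from compound 3 to compound 4 (0.18 log units; that floor lies within the scatter). Going by these compounds alone, with 3-phenylpropyl, as with phenyl and 2-chlorophenyl, the read-out is a limit, so 4-chlorophenyl remains the only group here with an actual number: the limit of > 137000 nM in this assay, at which 1 of the 4 values shown sits. The steps from compound 1 and from compound 2 to compound 4 cannot be read, since both ends are limits. Still open, from the compounds shown here alone, is whether any group on this nitrogen moves the number beyond the scatter. A longer chain, or a chain carrying an amine or a carboxylic acid, would test this.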